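The source may report more compounds than this note shows. Statements on the series, on what has been measured and on what is new or still open speak of the compounds shown alone.

Within the data shown here, compound 1 `COc1cc2c(Oc3ccc(NC(=O)c4cc(-c5ccccc5F)ccn4)cc3F)ccnc2cc1OCCCN1CCCCC1` is one of three compounds measured in a functional assay on HT-29 cells (Homo sapiens) for cytotoxicity, read by MTT assay, with a stated time of 72 h (a higher number here means a weaker inhibitor, a lower number a stronger inhibitor), where compound 1 gives 320 nM. Among the three numbers this is the highest, but the gap to the others is small. Among the measured compounds shown here, compound 2 `COc1cc2c(Oc3ccc(NC(=O)c4cc(-c5ccc(C(F)(F)F)cc5)ccn4)cc3F)ccnc2cc1OCCCN1CCCCC1` gives 230 nM, and the only single-point step in the set, a 1.4-fold lower number from compound 1 to compound 2 (0.14 log units; within the scatter), is within the scatter. Compound 3 `COc1cc2c(Oc3ccc(NC(=O)c4cc(-c5ccccc5C)ccn4)cc3F)ccnc2cc1OCCCN1CCN(C)CC1` gives 180 nM; it differs from compound 1 in two places at once, so its value and that of compound 1 can only be set side by side, and they, too, fall within the scatter of each other.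

Compound 4 `COc1cc2c(Oc3ccc(NC(=O)c4cc(-c5ccccc5F)ccn4)cc3F)ccnc2cc1OCCCN1CCCC1` has not yet been measured. The change from compound 1 is pyrrolidin-1-yl in place of piperidin-1-yl on a saturated chain carbon, three bonds along the chain from an oxygen on an aromatic ring. For the measured compounds named here, no measured step in this set touches the amine at the end of the chain: the one step on record concerns the aryl group on the other side of the core, and compound 3 changes the amine only together with the aryl group. With nothing pointing either way, the step of a 1.1-fold lower number from compound 1 to compound 4 (0.03 log units; within the scatter) is expected to stay within the scatter. Compound 4 is therefore estimated at 300 nM, with a range from 130 nM to 700 nM in this assay.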

Compound 4, half-maximal inhibitory concentration: 230 nM
Estimate against measurement, compound 4: 1.3-fold (0.12 log units) above, and the stated range covers the measured number.
By their numbers in this assay, from the lowest: compounds 3, 2, 4 and 1 (each within the scatter of the next).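

Among these compounds, compound 4 provides the first reading of a single change at the amine end of the chain: in this assay, pyrrolidin-1-yl in place of piperidin-1-yl gives a 1.4-fold lower number from compound 1 to compound 4 (0.14 log units; within the scatter). The earlier compounds shown here showed a change of amine only together with a change of aryl group, whereas this pair isolates the end of the chain, and here the five-membered ring and the six-membered ring cannot be told apart within the scatter. This holds for this one pair, with the 2-fluorophenyl group in place on the other side of the shared core, and nothing available here offers an explanation for the result.

The compounds shown leave open whether an open-chain amine such as dimethylamino, or a morpholine ring, would also stay within the scatter at the end of the chain, and whether a shorter or longer chain than the propyl linker would do the same. They also leave open whether the exchange of piperidin-1-yl for pyrrolidin-1-yl reads the same with the 4-(trifluoromethyl)phenyl group of compound 2 in place of the 2-fluorophenyl group.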